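A few compounds are considered here, and "the series" means these few. Any claim that something is new, unique, unknown or untested is made for them only; others in the source may bear on it.

In a physicochemical assay for solubility, with a stated time of 4 h, at pH 2.0 (on this read-out lower numbers stand for lower solubility and higher numbers for higher solubility), compound 3 (`COC(=O)c1cc(N)c(Nc2ccc(C#N)cc2)cc1Oc1c(C)cc(/C=C/C#N)cc1C`) gives 1.75 ug/mL as the second highest of three numbers. Compound 1 (`Cc1cc(/C=C/C#N)cc(C)c1Oc1cc(Nc2ccc(C#N)cc2)c(N)cc1C(N)=O`) gives 2.09 ug/mL and sits within the scatter of compound 3, while compound 2 (`Cc1cc(CCC#N)cc(C)c1Oc1cc(Nc2ccc(C#N)cc2)c(N)cc1C(F)(F)F`) gives 0.33 ug/mL and lies lower, beyond the scatter. Compound 4 (`Cc1cc(/C=C/C#N)cc(C)c1Oc1cc(Nc2ccc(C#N)cc2)c(N)cc1C(F)(F)F`) departs from compound 3 by trifluoromethyl in place of methoxycarbonyl on an aromatic carbon. Going by the values given here, the one measured step at that carbon (a 1.2-fold lower number from compound 1 to compound 3 (0.08 log units; within the scatter)) stayed within the scatter, yet it keeps the carbonyl. Compound 2 also carries trifluoromethyl and gives 0.33 ug/mL but differs from compound 3 elsewhere as well, so it is only a partial guide. A fall beyond the scatter is therefore expected (a 2.9-fold lower number from compound 3 to compound 4 (0.46 log units; beyond the scatter)). Compound 4 is estimated at 0.6 ug/mL with an expected range from 0.2 ug/mL to 1.6 ug/mL in this read-out.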

Compound 4, solubility: 0.42 ug/mL
For compound 4 the middle estimate is 1.4-fold (0.15 log units) above the measured one, within the range that was stated.
By their numbers in this assay, from the lowest: compounds 2 and 4 (each within the scatter of the next); then compounds 3 and 1 (each within the scatter of the next).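

At this aromatic carbon, trifluoromethyl departs clearly from both carbonyl-bearing groups in this assay: there is a 4.2-fold lower number from compound 3 to compound 4 (0.62 log units; beyond the scatter), and a 5.0-fold lower number from compound 1 to compound 4 (0.70 log units; beyond the scatter), whereas methoxycarbonyl and carbamoyl stayed within the scatter of each other. The other single change, 2-cyanoethenyl in place of 2-cyanoethyl, gives a 1.3-fold higher number from compound 2 to compound 4 (0.10 log units; within the scatter), so the unsaturation of that chain makes no measurable difference with trifluoromethyl in place. The low number of compound 2 therefore goes with trifluoromethyl in these compounds, not with its saturated chain.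

The data offer no measured explanation for the fall. From the compounds shown here alone, whether it follows from losing the carbonyl or from trifluoromethyl itself stays open, and a carboxylic acid or a methyl group at this carbon would help separate the two.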